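One Trifluoromethyl Removed From a Bis-Trifluoromethyl Anilide

The source may hold more compounds than are shown below. What is called first, only, known or untested is meant among the compounds shown, and "the series" means these compounds.

Compound 1 `O=C(Nc1cc(C(F)(F)F)cc(C(F)(F)F)c1)c1nccc2ccccc12` and compound 2 `O=C(Nc1cccc(C(F)(F)F)c1)c1nccc2ccccc12` are built on one core, while compound 3 `O=C(Nc1cc(C(F)(F)F)cc(C(F)(F)F)c1)C1c2ccccc2CCN1C(=O)c1ccc(Cl)cc1` and compound 4 `O=C(Nc1cccc(C(F)(F)F)c1)C1c2ccccc2CCN1C(=O)c1ccc(Cl)cc1` are built on another; the difference between the two cores is not broken down here. In a functional assay on NUGC-3 cells (Homo sapiens) for inhibition, read by sulforhodamine B assay, with a stated time of 48 h (a higher number here means a weaker inhibitor of growth, a lower number a stronger inhibitor of growth), compound 1 gives only a limit, > 10000 nM. Compound 2 likewise gives only a limit in this assay, > 10000 nM. The change between them, (hydrogen in place of trifluoromethyl on an aromatic carbon), thus made a step that the two limits leave unreadable from compound 1 to compound 2 because both results sit at the limit of > 10000 nM in this assay, at which 2 of the 3 values shown sit.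

Going by the values given here, compound 3 is the one measured compound that yields a number in this assay, 2830 nM. Compound 4 is reached from compound 3 by the same kind of change, (hydrogen in place of trifluoromethyl on an aromatic carbon), and the description of the place is the same word for word as for the earlier pair.

Since the earlier step cannot be read, the expectation for compound 4 rests on what compound 3 gives, 2830 nM, and on the fact that the change removes a trifluoromethyl group from the anilide ring. Compound 4 is therefore expected to give about 6000 nM in this assay, with a plausible span from 2000 nM to 20000 nM. That estimate means an expected step of a 2.1-fold higher number from compound 3 to compound 4 (0.33 log units; beyond the scatter), and it is quite possible that compound 4 too will return only a limit.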

Compound 4, concentration for 50% growth inhibition: > 10000 nM
Compound 4: a limit, no number; the forecaster's own chance of this, stated with the estimate: 35%; at least 1.6-fold (0.22 log units) between middle value and limit.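

In this assay, replacing one trifluoromethyl on the anilide ring with hydrogen on the core of compound 3 gives an at least 3.5-fold higher number from compound 3 to compound 4 (0.54 log units; beyond the scatter), so on this core the loss of that group goes with weaker growth inhibition, by a margin beyond the usual scatter. Compound 4 gives only a limit, > 10000 nM. This shows the effect of the change on one core only, and it does not show that the effect carries from one core to the other, because the step on the core of compound 1 cannot be read and the one readable step therefore has no counterpart to be set against: the limit of > 10000 nM in this assay, at which 3 of the 4 values shown sit.

Going by these compounds, only trifluoromethyl and hydrogen are compared at this place, so it remains open whether a nitrile, a methoxy group or an amine there would keep growth inhibition near that of compound 3, 2830 nM, in this assay. On these data alone, it is also open whether the same change would give a similar step if the chlorobenzoyl group on the core of compound 3 were replaced by an acetyl group or a chain ending in a carboxylic acid.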